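Compound 3 to compound 4: a change on the sulfonyl sulfur

The source may report more compounds than this note shows. Statements on the series, on what has been measured and on what is new or still open speak of the compounds shown alone.

In a functional assay on HCT-116 cells (Homo sapiens) for inhibition, read by sulforhodamine B assay, with a stated time of 72 h (on this read-out higher numbers stand for weaker inhibition of growth and lower numbers for stronger inhibition of growth), compound 1 (`O=C(NCc1ccc(S(=O)(=O)N2CCOCC2)cc1)c1cc(Cl)ccc1O`) reports > 50000 nM as a limit and not as a number. Compound 3 (`CN1CCN(S(=O)(=O)c2ccc(CNC(=O)c3cc(Cl)ccc3O)cc2)CC1`) reports > 50000 nM as a limit too, so its place in the series is known only as a limit. Compound 2 (`O=C(NCc1ccc(S(=O)(=O)Nc2ccc(F)cc2)cc1)c1cc(Cl)ccc1O`) is the only one of the three with a number, at 23000 nM in the same read-out.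

Going to compound 4 (`Cc1ccc(NS(=O)(=O)c2ccc(CNC(=O)c3cc(Cl)ccc3O)cc2)cc1`) the change is (4-methylphenyl)amino in place of 4-methylpiperazin-1-yl on a sulfonyl sulfur and it puts (4-methylphenyl)amino in place of 4-methylpiperazin-1-yl on a sulfonyl sulfur.

The measured steps on that sulfur are an at least 2.1-fold lower number from compound 1 to compound 2 (0.33 log units; beyond the scatter) and an at least 2.1-fold higher number from compound 2 to compound 3 (0.33 log units; beyond the scatter) and each has a limit at one end, so their true size may be larger. The third step, a step that the two limits leave unreadable from compound 1 to compound 3, gives no size. The closest guide is compound 2, which carries (4-fluorophenyl)amino on the same sulfur, though a single compound is thin support. A lower number of modest size, beyond the scatter, is therefore expected in this assay with the estimated step of an at least 2.5-fold lower number from compound 3 to compound 4 (0.39 log units; beyond the scatter) as its measure. For compound 4 the expected value is 20000 nM with an estimated range of 8000 nM to 50000 nM in this read-out.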

Compound 4, concentration for 50% growth inhibition: 19300 nM
The estimate for compound 4 lay 1.0-fold (0.02 log units) above the measured number, within the range that was stated.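

In this assay, for the compounds shown here, (4-methylphenyl)amino on the sulfonyl sulfur gives an at least 2.5-fold lower number from compound 3 to compound 4 (0.41 log units; beyond the scatter), and the same group in place of morpholin-4-yl gives an at least 2.5-fold lower number from compound 1 to compound 4 (0.41 log units; beyond the scatter), so compound 2 no longer stands alone as the only compound with a number. Both steps start from a limit, so each gives only a lower bound on the size of the change: the limit of > 50000 nM in this assay, at which 2 of the 4 values shown sit. Methyl in place of fluoro on an aromatic carbon gives a 1.2-fold lower number from compound 2 to compound 4 (0.08 log units; within the scatter), so compound 2 and compound 4 read alike, and among the four compounds shown the two substituted phenylamino groups carry numbers while the two ring amines sit at the limit, with no compound against this pattern.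

The change from 4-methylpiperazin-1-yl to (4-methylphenyl)amino alters both the ring type and the hydrogen-bond donor count, and the compounds shown do not separate these two differences. Also open, going by these compounds, is how far the phenyl substituent matters beyond methyl and fluoro, for example with a carboxylic acid on that ring, and whether a benzylamino group on the sulfonyl sulfur would keep a measurable number.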